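Series notes: from compound 3 to compound 4

The compounds below may be only part of what the source reports. "The series", "measured", "known", "first", "only" and "open" are said of these compounds alone.

Measured in an ADME assay on microsomes from liver (Mus musculus) for metabolic stability, read by LC-MS, with NADPH named in the record, with a stated time of 60 min, tested at 1 uM, in the absence of a further agent; on this read-out lower numbers stand for a less stable compound and higher numbers for a more stable compound:
- compound 1 `COc1ccc(-c2c(C)oc3c(N4CC[C@@H](NC(C)=O)C4)cc(C)nc23)cc1OC`: > 95%
- compound 2 `COc1ccc(-c2scc3c(N4CC[C@@H](NC(C)=O)C4)nc(C)nc23)cc1OC`: > 95%
- compound 3 `CC(=O)N[C@@H]1CCN(c2cc(C)nn3c(-c4ccccc4)c(C)nc23)C1`: > 95%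

All three entries are limits and not numbers, so the set shows (the limit of > 95% in this assay, at which 3 of the 3 values shown sit). Compound 3 therefore stands only at > 95%, which is a limit. Within the data shown here, no two measured compounds differ in one place, so no measured step is available.

Compound 4 `COc1ccc(-c2c(C)nc3c(N4CC[C@@H](NC(C)=O)C4)cc(C)nn23)cc1F` is reached from compound 3 by one change: 3-fluoro-4-methoxyphenyl in place of phenyl on an aromatic carbon. It puts 3-fluoro-4-methoxyphenyl in place of phenyl on an aromatic carbon.

Compound 1, on a different core, carries methoxy groups on its aromatic ring and gives > 95%, a limit. Compound 2, also on a different core and also bearing methoxy groups, gives > 95%, again a limit. On this basis, little change is expected in this assay, with any drop not expected to go beyond the scatter. The expected step is a number at least 3 percentage points lower from compound 3 to compound 4 (that floor lies within the scatter).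

The estimated value for compound 4 is 92%, with an expected range of 75% to 100%.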

Compound 4, percent of the compound remaining: > 95%
Compound 4: a limit, no number; the forecaster's own chance of this, stated with the estimate: 45%; middle value at least 3 percentage points away from the limit.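

Compound 3 and compound 4 both stand at a limit and not at a number in this assay, so no step can be read between them: the limit of > 95% in this assay, at which 4 of the 4 values shown sit.

The compounds shown leave open whether 3-fluoro-4-methoxyphenyl in place of phenyl alters stability in this assay at all, and by how much.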